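From 4-methylpentyl to hexyl: working notes

The source may report more compounds than this note shows. Statements on the series, on what has been measured and on what is new or still open speak of the compounds shown alone.

In a functional assay on ACHN cells (Homo sapiens) for antiproliferative activity, read by sulforhodamine B assay (a lower number here means a stronger inhibitor of growth, a higher number a weaker inhibitor of growth), compound 1 `CC(C)CCCOc1cccc(O)c1C(=O)/C=C/c1ccc(O)cc1` gives 3630 nM, the lower of the two numeric values in the series. Compound 3 `CC(C)(C)CCOc1cccc(O)c1C(=O)/C=C/c1ccc(C(=O)O)cc1` gives 8450 nM, a higher number than compound 1, and the gap lies beyond the scatter. Compound 2 `COc1cccc(OCCC(C)(C)C)c1C(=O)/C=C/c1ccc(O)cc1` reads > 30000 nM, which is a limit of the assay and not a number.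

The next compound to be tested is compound 4 `CCCCCCOc1cccc(O)c1C(=O)/C=C/c1ccc(O)cc1`. It has propyl in place of isopropyl on a saturated chain carbon, three bonds along the chain from an oxygen on an aromatic ring. Cut one bond further out, the same difference reads 4-methylpentyl to hexyl.

Within the data shown here, no measured pair shows this change, so the expectation rests on compound 1 at 3630 nM and on the structural change alone. No step beyond the scatter is expected in this assay. The estimated step of a 1.1-fold higher number from compound 1 to compound 4 (0.04 log units; within the scatter) is expected to be small, with no firm direction. For compound 4, the expected value is 4000 nM, with an estimated range of 1800 nM to 9500 nM.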

Compound 4, concentration for 50% growth inhibition: > 30000 nM
Compound 4: no number, only a limit; the forecaster's own chance of this, stated with the estimate: 5%; middle value at least 7.5-fold (0.87 log units) from the limit.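

In this assay, the series now holds its first single-place comparison, and the change is not neutral: propyl in place of isopropyl at this saturated chain carbon gives an at least 8.2-fold higher number from compound 1 to compound 4 (0.91 log units; beyond the scatter), although the two compounds have the same atoms, joined differently. Among the compounds shown, the only difference between a numeric value and this result is therefore the isopropyl end of the chain in compound 1 against the unbranched hexyl chain in compound 4. The compound 4 end of this step is a limit of the assay and not a number: the limit of > 30000 nM in this assay, at which 2 of the 4 values shown sit.

From the compounds shown here alone, the size of the step beyond that limit remains unknown. Also open, going by these compounds, is whether an octyl chain, or an amine at the end of the chain, would give a numeric value in this assay.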